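Swapping 3,5-dimethylphenyl for thiophen-2-yl

A few compounds are considered here, and "the series" means these few. Any claim that something is new, unique, unknown or untested is made for them only; others in the source may bear on it.

Compound 1 `COC1=C(C)C(=O)/C(=C(O)/C=C/c2cccc(OC)c2)C(=O)C1(C)C`: 4.5 ug/mL
Compound 2 `COC1=C(C)C(=O)/C(=C(O)/C=C/c2cc(C)cc(C)c2)C(=O)C1(C)C`: 4 ug/mL

In a functional assay on A-431 cells (Homo sapiens) for cytotoxicity (on this read-out lower numbers stand for an effect already at smaller amounts and higher numbers for an effect only at larger amounts of compound), compound 2 gives 4 ug/mL, which cannot be told apart from compound 1 at 4.5 ug/mL. Compound 3 `COC1=C(C)C(=O)/C(=C(O)/C=C/c2cccs2)C(=O)C1(C)C` keeps the shared core but exchanges the aromatic group: thiophen-2-yl in place of 3,5-dimethylphenyl on a double-bonded chain carbon bound to a double-bonded chain carbon. For the measured compounds named here, only one measured step bears on this change, a swap in the same place: a 1.1-fold lower number from compound 1 to compound 2 (0.05 log units; within the scatter). That step stayed within the scatter, so this assay has not yet responded to any change at this position. Going by the values given here, it is only a weak guide, though, since no compound with a five-membered aromatic ring has been measured. The expected result is therefore no shift beyond the scatter, with a wide margin for the new ring. The estimated change is a 1.3-fold higher number from compound 2 to compound 3 (0.10 log units; within the scatter). For compound 3 the expected value is 5 ug/mL, within an estimated range of 2 ug/mL to 12 ug/mL.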

Compound 3, concentration for half-maximal effect: 10.8 ug/mL
Beside the measured number, compound 3's estimate is 2.2-fold (0.33 log units) below it; measured number inside the range.
By their numbers in this assay, from the lowest: compounds 2 and 1 (each within the scatter of the next); then compound 3.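

In this assay this position is not indifferent after all: thiophen-2-yl brings a 2.7-fold higher number from compound 2 to compound 3 (0.43 log units; beyond the scatter) and also a 2.4-fold higher number from compound 1 to compound 3 (0.38 log units; beyond the scatter) when it replaces 3-methoxyphenyl. Compound 1 and compound 2 cannot be told apart, so two differently substituted six-membered aromatic rings behave alike here, whereas the five-membered aromatic ring with a sulfur atom needs a larger amount of compound for the same effect. Nothing available explains this shift.

The compounds shown leave open whether the ring size, the sulfur atom or the loss of the methyl or methoxy groups matters most. A plain phenyl, a furan-2-yl or a thiophen-2-yl carrying a methyl group could help separate these possibilities, and a ring bearing an amine would test a different kind of group at this position.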